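Adding Bromo to a Compound at the Limit

A few compounds are considered here, and "the series" means these few. Any claim that something is new, unique, unknown or untested is made for them only; others in the source may bear on it.

Compound 1 `S=C(N/N=C/c1cccs1)Nc1ccccc1` has been tested in a functional assay on UACC-62 cells (Homo sapiens) for inhibition, read by sulforhodamine B assay, with a stated time of 48 h (on this read-out lower numbers stand for stronger inhibition of growth and higher numbers for weaker inhibition of growth), where compound 1 gives > 100000 nM, which is a limit of the assay and not a number. Compound 2 `S=C(N/N=C/c1cccs1)Nc1cccnc1` gives > 100000 nM in this assay, which is also a limit. Compound 1 therefore stands at the limit of > 100000 nM in this assay, at which 2 of the 2 values shown sit. Going by the values given here, no exact value places it on the scale, and no step between measured compounds is available as a guide.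

Compound 3 `S=C(N/N=C/c1cccs1)Nc1ccc(Br)cc1` departs from compound 1 in one place: bromo in place of hydrogen on an aromatic carbon. The change is bromo in place of hydrogen on an aromatic carbon, para to a large group. With nothing measured to size such a change, only a small move towards stronger inhibition of growth is expected in this assay, and a step no larger than the scatter would be unsurprising. The estimated step is an at least 1.4-fold lower number from compound 1 to compound 3 (0.15 log units; that floor lies within the scatter). The assay may well report only a limit again for compound 3. For compound 3 the expected value is 70000 nM, with an estimated range from 20000 nM to 150000 nM.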

Compound 3, concentration for 50% growth inhibition: 71100 nM
Compound 3: the middle estimate sits 1.0-fold (0.01 log units) below what was measured; measured number inside the range.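

Bromo in place of hydrogen on an aromatic carbon, para to a large group, gives the first exact number in this series in this assay; the change reads as an at least 1.4-fold lower number from compound 1 to compound 3 (0.14 log units; that floor lies within the scatter). Compound 1 has only a limit to start from, so this step is a floor, and the data do not tell whether the real step is small or much larger. This position on the six-membered aromatic ring of carbon only therefore accepts bromo and brings compound 3 onto the measurable scale, while the other compounds shown stay at the limit: the limit of > 100000 nM in this assay, at which 2 of the 3 values shown sit.

What the compounds shown leave open is whether this result belongs to bromo in particular or would also appear with another group in the same place, such as chloro, methoxy, an amine or a carboxylic acid. They also leave open whether bromo would bring a number within range on the core of compound 2, and whether the same group on another carbon of the ring would read the same in this assay.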